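The source may report more compounds than this note shows. Statements on the series, on what has been measured and on what is new or still open speak of the compounds shown alone.

Working notes on an ADME assay on MCF7 cells (Homo sapiens) for inhibition; on this read-out higher numbers stand for weaker inhibition and lower numbers for stronger inhibition. Compound 1 (`COC(=O)c1cc2c(F)c(F)c(Sc3ccc(C(C)(C)C)cc3)c(F)c2s1`) has no number here, only a limit of > 50000 nM. Compound 2 (`O=C(c1ccccc1)c1cc2c(F)c(F)c(-n3ccnc3)c(F)c2s1`), which carries benzoyl, likewise returns only a limit, > 60000 nM. Among the measured compounds shown here, the series therefore offers no measured step, and compound 1 can be placed only by its limit.

Compound 3 (`CC(C)(C)c1ccc(Sc2c(F)c(F)c3cc(C(=O)c4ccccc4)sc3c2F)cc1`) keeps the core of compound 1 and changes one group, methoxycarbonyl to benzoyl: phenyl in place of methoxy on a carbonyl carbon. That is phenyl in place of methoxy on a carbonyl carbon. No change beyond the scatter is expected, and another limit is the likeliest report. This expectation rests on compound 2, which already has benzoyl and gives the limit > 60000 nM. The estimated step of an at least 1.1-fold lower number from compound 1 to compound 3 (0.04 log units; that floor lies within the scatter) is expected to stay small. For compound 3 the expected value is 45000 nM, with an estimated range of 15000 nM to 100000 nM.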

Compound 3, half-maximal inhibitory concentration: > 25000 nM
Compound 3: no number, only a limit (the forecaster's own chance of this, stated with the estimate: 70%); the middle value lies beyond the limit too.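

Among the compounds shown here, compound 3 returns only a limit, > 25000 nM, and compound 1 also stands only as a limit, so no step between them can be read. The compounds shown leave open how methoxycarbonyl and benzoyl compare in this assay, since none has a measured number.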